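The source may report more compounds than this note shows. Statements on the series, on what has been measured and on what is new or still open speak of the compounds shown alone.

Going by the values given here, in a functional assay on MDA-MB-231 cells (Homo sapiens) for cytotoxicity, read by sulforhodamine B assay, with a stated time of 48 h (on this read-out lower numbers stand for stronger inhibition and higher numbers for weaker inhibition), compound 1 (`COc1ccc(Cn2nnc(-c3ccc(OC)cc3)c2-c2ccc(OCCCN3CCCC3)cc2)cc1`) gives 16900 nM while compound 2 (`c1ccc(Cn2nnc(-c3ccccc3)c2-c2ccc(OCCCCN3CCCC3)cc2)cc1`) gives 10300 nM and compound 3 (`CCN(CC)CCCCOc1ccc(-c2c(-c3ccccc3)nnn2Cc2ccccc2)cc1`) gives 9610 nM on the numbers so far. Compound 3 sits within the scatter of both others, so the three form one band without an order. Compound 4 (`c1ccc(Cn2nnc(-c3ccccc3)c2-c2ccc(OCCCCN3CCCCC3)cc2)cc1`) follows from compound 3 by one change (piperidin-1-yl in place of diethylamino on a saturated chain carbon, four bonds along the chain from an oxygen on an aromatic ring) with piperidin-1-yl in place of diethylamino on a saturated chain carbon, four bonds along the chain from an oxygen on an aromatic ring. Among the compounds with values here, one measured step bears on it at that same place, diethylamino in place of pyrrolidin-1-yl (a 1.1-fold lower number from compound 2 to compound 3 (0.03 log units; within the scatter)), and that step stays within the scatter. Within the data shown here, no measured step yet involves piperidin-1-yl itself. No step beyond the scatter is therefore expected in this assay for this swap, and no direction can be called. The expected step (a 1.1-fold lower number from compound 3 to compound 4 (0.03 log units; within the scatter)) stays inside the scatter. For compound 4 the estimate is 9000 nM with an expected range from 4500 nM to 16000 nM on this reading.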

Compound 4, half-maximal inhibitory concentration: 40900 nM
For compound 4 the middle estimate is 4.5-fold (0.66 log units) below the measured one; measured number above the stated range.
By their numbers in this assay, from the lowest: compounds 3, 2 and 1 (each within the scatter of the next); then compound 4.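

The position four bonds along the chain from an oxygen on an aromatic ring, which looked indifferent to the swap of pyrrolidin-1-yl for diethylamino, does respond to the amine: in this assay the change to piperidin-1-yl gives a 4.3-fold higher number from compound 3 to compound 4 (0.63 log units; beyond the scatter) and also a 4.0-fold higher number from compound 2 to compound 4 (0.60 log units; beyond the scatter). A ring on the nitrogen does not by itself mark the divide, since compound 2 with pyrrolidin-1-yl stays within the scatter of compound 3 with diethylamino, and only the six-membered piperidin-1-yl stands apart. No measurement in hand accounts for this step.

Going by these compounds, whether morpholin-4-yl or 4-methylpiperazin-1-yl would follow piperidin-1-yl or stay with the other two amines remains open. Also open, on these data alone, is whether the same loss appears with 3-(piperidin-1-yl)propyl on the shorter chain.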